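Swapping the Aryl Group on the Shared Core

The source may hold more compounds than are shown below. What is called first, only, known or untested is meant among the compounds shown, and "the series" means these compounds.

Compound 2 `COc1ccc(C2C(C#N)=C(N)OC(c3c[nH]c4ccccc34)=C2C#N)cc1OC` carries a 3,4-dimethoxyphenyl group on a saturated ring carbon of the shared core. In a functional assay on MCF7 cells (Homo sapiens) for cytotoxicity, read by MTT assay, with a stated time of 24 h (a lower number here means a stronger inhibitor of growth, a higher number a weaker inhibitor of growth), compound 2 gives 20600 nM. Within the data shown here, this is the lower of the two numbers recorded so far, although the gap to its only neighbour is within the scatter: compound 1 `N#CC1=C(N)OC(c2c[nH]c3ccccc23)=C(C#N)C1c1ccc(Br)cc1`, which bears 4-bromophenyl at the same place, gives 21800 nM in this assay. Among the measured compounds shown here, the one measured step, a 1.1-fold lower number from compound 1 to compound 2 (0.02 log units; within the scatter), shows that exchanging one aryl group for another at this carbon left the growth-inhibiting effect essentially unchanged.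

Compound 3 `N#CC1=C(N)OC(c2c[nH]c3ccccc23)=C(C#N)C1c1cccc2ccccc12` is the next variation at the same position: naphthalen-1-yl in place of 3,4-dimethoxyphenyl on a saturated ring carbon. For the measured compounds named here, the only step that bears on this change is the one from compound 1 to compound 2, and it stayed within the scatter. Since both of the measured aryl groups give the same outcome, no step beyond the scatter is expected in this assay; the expected step of a 1.0-fold lower number from compound 2 to compound 3 (0.01 log units; within the scatter) is therefore flat. Compound 3 is expected to give about 20000 nM, within a range of 8000 nM to 50000 nM.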

Compound 3, concentration for 50% growth inhibition: 18200 nM
Beside the measured number, compound 3's estimate is 1.1-fold (0.04 log units) above it, within the range that was stated.
By their numbers in this assay, from the lowest: compounds 3, 2 and 1 (each within the scatter of the next).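

Naphthalen-1-yl brings a second six-membered aromatic ring of carbon only and carries none of the 2 hydrogen-bond acceptors of 3,4-dimethoxyphenyl, yet in this assay this exchange gives only a 1.1-fold lower number from compound 2 to compound 3 (0.05 log units; within the scatter) and no real shift in growth inhibition. The exchange for 4-bromophenyl reads the same way, with a 1.2-fold lower number from compound 1 to compound 3 (0.08 log units; within the scatter), so the three aryl groups at this saturated ring carbon cannot be told apart in this assay, and neither the number of aromatic rings nor the presence of those acceptors separates them. No further measurement bears on why these three compounds read alike.

On these data alone, all three groups at this carbon are aryl groups, so it remains open whether an amine, a carboxylic acid or a longer alkyl chain in the same place would move the number beyond the scatter. As far as these compounds go, the 1H-indol-3-yl group, the amino group and the two cyano groups are the same in all three compounds, so what each of them contributes to growth inhibition also remains unknown.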